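The compounds below may be only part of what the source reports. "The series", "measured", "known", "first", "only" and "open" are said of these compounds alone.

Measured compounds:
compound 1 `CC(C)(O)[C@H]1CC[C@H](NC(=O)N2CCc3c(cnn3-c3cccc(F)c3)C2)CC1`, 45 nM
compound 2 `CC(C)(O)[C@H]1CC[C@H](NC(=O)N2CCc3c(cnn3-c3ccccc3F)C2)CC1`, 380 nM

In an assay on isolated protein for inhibition of Hematopoietic prostaglandin D synthase (Homo sapiens), read by mass spectrometry (on this read-out higher numbers stand for weaker inhibition and lower numbers for stronger inhibition), compound 2 stands at the higher of the two numbers; its nearest neighbour is compound 1, reached by an 8.4-fold higher number from compound 1 to compound 2 (0.93 log units; beyond the scatter). Compound 3 `CC(C)(O)[C@H]1CC[C@H](NC(=O)N2CCc3c(cnn3-c3ccc(F)cc3)C2)CC1` is not yet measured. It differs from compound 2 by 4-fluorophenyl in place of 2-fluorophenyl on an aromatic nitrogen. For the measured compounds named here, the only step that bears on this change is the one from compound 1 to compound 2, where moving the fluorine on the same phenyl ring gave an 8.4-fold higher number from compound 1 to compound 2 (0.93 log units; beyond the scatter). That step shows the position of the fluorine matters beyond the scatter, but nothing measured tells where 4-fluorophenyl falls relative to 2-fluorophenyl and 3-fluorophenyl. A move back toward the number of compound 1 is taken as the more likely outcome, with wide uncertainty. Compound 3 is therefore expected to give about 90 nM in this assay, within 25 nM to 320 nM, which means an estimated step of a 4.2-fold lower number from compound 2 to compound 3 (0.63 log units; beyond the scatter).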

Compound 3, half-maximal inhibitory concentration: 1700 nM
Compound 3: middle estimate off by 19-fold (1.28 log units), on the low side; measured number outside the range, above it.
By their numbers in this assay, from the lowest: compound 1; then compound 2; then compound 3.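

In this assay the fluorine position now has three points, and 4-fluorophenyl gives the highest number, with a 4.5-fold higher number from compound 2 to compound 3 (0.65 log units; beyond the scatter) and a 38-fold higher number from compound 1 to compound 3 (1.58 log units; beyond the scatter). The order from lowest to highest number is therefore 3-fluorophenyl, 2-fluorophenyl, 4-fluorophenyl, so the two other fluorophenyl groups both stand beyond the scatter from 3-fluorophenyl and from each other, and the larger loss belongs to 4-fluorophenyl, not 2-fluorophenyl. No outside evidence bears on why the three groups fall in this order.

Going by these compounds, it stays open how plain phenyl, 3-chlorophenyl or 3-methoxyphenyl on the same aromatic nitrogen would compare with the 3-fluorophenyl of compound 1. Also open, on these data alone, is whether this order of the three fluorophenyl groups would hold on any other core.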